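The compounds below may be only part of what the source reports. "The series", "measured", "known", "first", "only" and "open" are said of these compounds alone.

Measured in a functional assay on HeLa cells (Homo sapiens) for antiproliferative activity, read by MTT assay, with a stated time of 48 h; a lower number here means a stronger inhibitor, a higher number a weaker inhibitor:
- compound 1 `Brc1ccccc1CSc1nnc(-c2cnccn2)n1-c1ccccc1`: > 50000 nM (a limit of the assay)
- compound 2 `Brc1cccc(CSc2nnc(-c3cnccn3)n2-c2ccccc2)c1`: 9580 nM
- compound 3 `Fc1ccc(CSc2nnc(-c3cnccn3)n2-c2ccccc2)cc1`: 7300 nM

Compound 3 stands level with compound 2, with a 1.3-fold lower number from compound 2 to compound 3 (0.12 log units; within the scatter). Compound 4 `Brc1ccc(CSc2nnc(-c3cnccn3)n2-c2ccccc2)cc1` has bromo in place of fluoro on an aromatic carbon, para to a large group: bromo in place of fluoro on an aromatic carbon.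

Going by the values given here, no measured step makes this swap alone. The nearest is a 1.3-fold lower number from compound 2 to compound 3 (0.12 log units; within the scatter), which changes both halogen and place yet stays within the scatter. The larger steps, an at least 5.2-fold lower number from compound 1 to compound 2 (0.71 log units; beyond the scatter) and an at least 6.8-fold lower number from compound 1 to compound 3 (0.83 log units; beyond the scatter), both start from the limit of compound 1, so they bear less directly on the swap. The expected 1.0-fold lower number from compound 3 to compound 4 (0.02 log units; within the scatter) therefore stays within the scatter, with no firm direction. For compound 4 the estimated value is 7000 nM, with an expected range of 2800 nM to 18000 nM.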

Compound 4, half-maximal inhibitory concentration: 8630 nM
Compound 4: middle estimate off by 1.2-fold (0.09 log units), on the low side; low and high end bracket the measured number.
By their numbers in this assay, from the lowest: compounds 3, 4 and 2 (each within the scatter of the next). At a limit, above all of these: compound 1.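

In this assay, bromo and fluoro on an aromatic carbon, para to a large group, cannot be told apart: a 1.2-fold higher number from compound 3 to compound 4 (0.07 log units; within the scatter). The 4-bromophenyl and 3-bromophenyl groups also cannot be told apart, a 1.1-fold lower number from compound 2 to compound 4 (0.05 log units; within the scatter), whereas the step from 2-bromophenyl lies beyond the scatter: an at least 5.7-fold lower number from compound 1 to compound 4 (0.76 log units; beyond the scatter). The value of compound 1 is a limit of the assay, not a number: the limit of > 50000 nM in this assay, at which 1 of the 4 values shown sits.

On these data alone, it remains open whether an amine or a methoxy group on that aromatic carbon would shift the number beyond the scatter. As far as these compounds go, it is also open whether 2-fluorophenyl would sit with compound 1 or with compound 4.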